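The source may report more compounds than this note shows. Statements on the series, on what has been measured and on what is new or still open speak of the compounds shown alone.

The measured compounds:
Compound 1, `N#Cc1ccc(NCCNc2ncc(-c3ncc[nH]3)c(-c3ccc(Cl)cc3Cl)n2)nc1`, gives in an ADME assay on microsomes from liver (Rattus norvegicus) for metabolic stability (a higher number here means that the compound lasts longer, a lower number that the compound disappears faster), a value of > 0.5 h, which is a limit of the assay and not a number.
Compound 2, `FC(F)(F)c1ccc(NCCNc2ncc(-c3ncc[nH]3)c(-c3ccc(Cl)cc3Cl)n2)nc1`, gives in this assay > 0.5 h, again a limit.
Compound 3, `Nc1nc(NCCNc2ncc(-c3ncc[nH]3)c(-c3cc(F)c(F)cc3F)n2)ccc1[N+](=O)[O-]`, gives in this assay > 0.5 h, also a limit.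

Going by the values given here, compound 3 therefore stands at the limit of > 0.5 h in this assay, at which 3 of the 3 values shown sit, where every value shown sits, so no measured compound can be set apart from another in this assay. Among the compounds with values here, the one step between measured compounds, a step that the two limits leave unreadable from compound 1 to compound 2, is unreadable because a step that the two limits leave unreadable from compound 1 to compound 2 runs between two limits.

Compound 4, `Nc1nc(NCCNc2ncc(-c3ncc[nH]3)c(-c3ccc(Br)cc3Cl)n2)ccc1[N+](=O)[O-]`, differs from compound 3 in one place: 4-bromo-2-chlorophenyl in place of 2,4,5-trifluorophenyl on an aromatic carbon. Within the data shown here, no measured step involves this exchange, and the one step available gives no readable size at all. Among the measured compounds shown here, the account can therefore expect only that compound 4 will behave like compound 3 and sit at the same limit.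

Compound 4 is expected to give 0.8 h, within 0.4 h to 2 h, most probably reported once more as a limit. The expected step that the limit leaves unreadable from compound 3 to compound 4 is one that lies within the scatter.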

Compound 4, half-life: > 0.5 h
Compound 4 gave a limit, no number; the forecaster's own chance of this, stated with the estimate: 75%; the middle value is on the limit's open side.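

No step from compound 3 to compound 4 can be read, since both give only a limit of the assay and not a number: the limit of > 0.5 h in this assay, at which 4 of the 4 values shown sit.

The compounds shown leave open how long any of them actually lasts in this assay, and whether 4-bromo-2-chlorophenyl in place of 2,4,5-trifluorophenyl alters that half-life at all.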